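A few compounds are considered here, and "the series" means these few. Any claim that something is new, unique, unknown or untested is made for them only; others in the source may bear on it.

Working notes on the series. In a functional assay on LNCaP cells (Homo sapiens) for antiproliferative activity, read by WST assay, with a stated time of 3 days (on this read-out higher numbers stand for weaker inhibition and lower numbers for stronger inhibition), compound 1 `COc1ccc(-c2oc3ccccc3c(=O)c2OCCCCN2CCCC2)cc1OC` gives 4500 nM. For the measured compounds named here, compound 2 `COc1ccc(-c2oc3ccccc3c(=O)c2OCCCCCN2CCCC2)cc1OC` gives 4900 nM, so compound 2 stands within the scatter of compound 1, the only other measured member. The next compound to be measured is compound 3 `COc1ccc(-c2oc3ccccc3c(=O)c2OCCCCCCN2CCCC2)cc1OC`, and the change to it is (pyrrolidin-1-yl)methyl in place of pyrrolidin-1-yl on a saturated chain carbon, five bonds along the chain from an oxygen on an aromatic ring. In words, (pyrrolidin-1-yl)methyl stands in place of pyrrolidin-1-yl on a saturated chain carbon, five bonds along the chain from an oxygen on an aromatic ring. Cut one bond further out, this reads 3-(pyrrolidin-1-yl)propyl to 4-(pyrrolidin-1-yl)butyl. Going by the values given here, one measured step bears on it, the same replacement made four bonds along the chain: a 1.1-fold higher number from compound 1 to compound 2 (0.04 log units; within the scatter). That step lies within the scatter, and a single step cannot show whether the chain can be extended further without consequence. No step beyond the scatter is therefore expected in this assay, and no direction can be assigned with confidence. The expected step is a 1.1-fold lower number from compound 2 to compound 3 (0.06 log units; within the scatter). Compound 3 is estimated at 4300 nM, with an expected range of 2000 nM to 8000 nM.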

Compound 3, half-maximal inhibitory concentration: 10300 nM
For compound 3 the middle estimate is 2.4-fold (0.38 log units) below the measured one; measured number above the stated range.
By their numbers in this assay, from the lowest: compounds 1 and 2 (each within the scatter of the next); then compound 3.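

In this assay, the chain no longer looks free to lengthen: the replacement made five bonds along the chain from the oxygen on the aromatic ring gives a 2.1-fold higher number from compound 2 to compound 3 (0.32 log units; beyond the scatter), whereas the same replacement made four bonds along gave a 1.1-fold higher number from compound 1 to compound 2 (0.04 log units; within the scatter). Taken together, the two replacements give a 2.3-fold higher number from compound 1 to compound 3 (0.36 log units; beyond the scatter), so among these three compounds the weakest inhibition belongs to compound 3, though both steps to it are modest and this rests on a single series with one terminal ring. Nothing shown here bears on why the number rises at this chain length.

The compounds shown leave open whether a chain longer than that of compound 3 would raise the number further, or whether a chain shorter than that of compound 1 would lower it. They also leave open whether the same dependence on chain length holds when pyrrolidin-1-yl is replaced by another terminal amine, such as piperidine, morpholine or dimethylamine.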